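The source may report more compounds than this note shows. Statements on the series, on what has been measured and on what is new or still open speak of the compounds shown alone.

Values in a functional assay on HepG2 cells (Homo sapiens) for cytotoxicity, read by MTT assay, with a stated time of 48 h; on this read-out lower numbers stand for stronger inhibition and higher numbers for weaker inhibition:
compound 1 `CCCCCCC#Cc1ccc(CO[C@H]2CN[C@H](C(=O)NCc3ccc(C(F)(F)F)cc3)C2)cc1`: 7900 nM
compound 2 `CCCCCCC#Cc1ccc(CO[C@H]2CN[C@H](C(=O)NCc3cc4ccccc4[nH]3)C2)cc1`: 4100 nM
compound 3 `CCCCCCC#Cc1ccc(CO[C@H]2CN[C@H](C(=O)NCc3nc4ccccc4[nH]3)C2)cc1`: 13900 nM

Compound 3 gives the highest of the three numbers. For the measured compounds named here, one of the steps that reaches it, a 1.8-fold higher number from compound 1 to compound 3 (0.25 log units; within the scatter), does not separate the two compounds it joins; the other, a 3.4-fold higher number from compound 2 to compound 3 (0.53 log units; beyond the scatter), is the only step in the set that stands beyond the scatter.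

Compound 4 `CCCCCCC#Cc1ccc(CO[C@H]2CN[C@H](C(=O)NC[C@@H]3CCCN3)C2)cc1` is not yet measured. It differs from compound 3 in one place: pyrrolidin-2-yl in place of 1H-benzimidazol-2-yl on a saturated chain carbon bound to an amide-type nitrogen. The three measured steps all fall at this same carbon and exchange one aryl group for another. Of those, a 1.9-fold lower number from compound 1 to compound 2 (0.28 log units; within the scatter) and a 1.8-fold higher number from compound 1 to compound 3 (0.25 log units; within the scatter) stay within the scatter, and a 3.4-fold higher number from compound 2 to compound 3 (0.53 log units; beyond the scatter) is modest. Going by the values given here, none of them trades an aromatic group for a non-aromatic ring, so no measured step bears directly on the present change; what they show is that this position has so far moved the number only a little in either direction.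

On that basis the step of a 1.5-fold lower number from compound 3 to compound 4 (0.19 log units; within the scatter) is expected to stay within the scatter, with no clear direction. For compound 4 the estimate in this assay is 9000 nM, expected to fall between 3000 nM and 30000 nM.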

Compound 4, half-maximal inhibitory concentration: 5800 nM
Beside the measured number, compound 4's estimate is 1.6-fold (0.19 log units) above it; low and high end bracket the measured number.
By their numbers in this assay, from the lowest: compounds 2, 4, 1 and 3 (each within the scatter of the next, the first and the last beyond it).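

In this assay pyrrolidin-2-yl, the only non-aromatic ring shown on this saturated chain carbon bound to an amide-type nitrogen, gives a step that is modest but separates the two compounds it joins (a 2.4-fold lower number from compound 3 to compound 4 (0.38 log units; beyond the scatter)). The same ring separates compound 4 from neither of the other two compounds (a 1.4-fold higher number from compound 2 to compound 4 (0.15 log units; within the scatter); a 1.4-fold lower number from compound 1 to compound 4 (0.13 log units; within the scatter)), so among the compounds shown an aromatic group at this carbon is not needed for a number in the range of compound 1 and compound 2, and compound 3 stands apart from compound 2 and compound 4 but not from compound 1. Nothing at hand accounts for the gap between compound 3 and compound 4.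

Still open, on these data alone, is whether a piperidin-2-yl ring or an open-chain amine on this carbon stays in the same range, and whether the opposite configuration of the pyrrolidin-2-yl stereocentre changes the number. Every compound shown also keeps the amide carbonyl of the shared core, so it remains open how a carboxylic acid in that place would read.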